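This account rests on a few compounds, and the source may have more. Where it says the series, first, only, none or still open, it means among the compounds named here.

Compound 1 `Cc1ccccc1-c1nn(C(C)C)cc1CNCCN1CCN(C)CC1` gives > 20000 nM in an ADME assay on Huh-7 cells (Homo sapiens) for cytotoxicity (a higher number here means that more compound is tolerated, a lower number that less compound is tolerated), which is a limit of the assay and not a number.
Compound 2 `CN1CCN(CCCNCc2cn(-c3ccc(C(F)(F)F)cc3)nc2-c2ccc(Cl)cc2)CC1` gives 2500 nM in this assay.
Compound 3 `CN1CCN(CCNCc2cn(-c3ccc(F)cc3F)nc2-c2ccccc2Cl)CC1` gives > 20000 nM in this assay, again a limit of the assay.

Compound 1 therefore stands at the limit of > 20000 nM in this assay, at which 2 of the 3 values shown sit. Compound 4 `Cc1ccccc1-c1nn(-c2ccc([N+](=O)[O-])cc2)cc1CNCCN1CCN(C)CC1` differs from it by 4-nitrophenyl in place of isopropyl on an aromatic nitrogen. Within the data shown here, no measured pair differs in a single place, so the size of this step is not known from measurement. Compound 2, which also carries an aryl group on an aromatic nitrogen, gives 2500 nM. Compound 3, also aryl-substituted there, gives only the limit > 20000 nM. A modest step toward lower tolerance is expected for compound 4, an at least 2.0-fold lower number from compound 1 to compound 4 (0.30 log units; that floor lies within the scatter), though it may lie within the scatter. Compound 4 is thus estimated at 10000 nM, between 2500 nM and 40000 nM.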

Compound 4, half-maximal cytotoxic concentration: > 20000 nM
Compound 4 ended at the assay's limit; the forecaster's own chance of this, stated with the estimate: 40%; middle value at least 2.0-fold (0.30 log units) from the limit.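

The results for compound 1 and compound 4 in this assay are both limits of the assay, and the step between them cannot be read. The compounds shown leave open how far 4-nitrophenyl in place of isopropyl changes the tolerated concentration, with most results sharing one limit: the limit of > 20000 nM in this assay, at which 3 of the 4 values shown sit.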